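The source may report more compounds than this note shows. Statements on the series, on what has been measured and on what is new or still open speak of the compounds shown alone.

Working notes on the benzothiazolyl-aniline amide series.

In an ADME assay on HepG2 cells (Homo sapiens) for inhibition, with a stated time of 72 h (on this read-out lower numbers stand for an effect already at smaller amounts and higher numbers for an effect only at larger amounts of compound), compound 1 `O=C(Nc1cccc(-c2nc3ccccc3s2)c1)c1cnccc1Cl` gives > 25000 nM, which is a limit of the assay and not a number. Compound 2 `O=C(Nc1cccc(-c2nc3ccccc3s2)c1)c1ccnc(Cl)c1` also gives a limit, > 25000 nM, in this assay. Compound 3 `O=C(Nc1cccc(-c2nc3ccccc3s2)c1)c1cnc(Cl)s1` is the third member, and in this assay compound 3 gives > 25000 nM, again a limit. Hence (the limit of > 25000 nM in this assay, at which 3 of the 3 values shown sit); none of the three measured compounds has a numerical value, and compound 1 can only be placed at that limit alongside the other two.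

The measured steps all concern the acyl part on the carbonyl carbon: a step that the two limits leave unreadable from compound 1 to compound 2, a step that the two limits leave unreadable from compound 1 to compound 3 and a step that the two limits leave unreadable from compound 2 to compound 3. Their sizes are not readable from two limits, so they give no scale for any change.

Compound 4 `O=C(Nc1ccc(F)c(-c2nc3ccccc3s2)c1)c1cnccc1Cl` differs from compound 1 in the aniline part: fluoro in place of hydrogen on an aromatic carbon. Among the measured compounds shown here, no measured step touches this ring, so nothing measured bears on the change directly. With every measured member at the limit, the expectation for this assay is that compound 4 remains near the limit as well, a step that the limit leaves unreadable from compound 1 to compound 4 that is expected to be within scatter or unreadable. The estimate for compound 4 in this assay is 30000 nM, in the range 12000 nM to 120000 nM.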

Compound 4, half-maximal effective concentration: > 25000 nM
Compound 4: a limit, no number (the forecaster's own chance of this, stated with the estimate: 80%); the middle value lies beyond the limit too.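

No new step can be read from compound 1 to compound 4, since both stand at a limit and not at a number: the limit of > 25000 nM in this assay, at which 4 of the 4 values shown sit.

The compounds shown leave open whether any change to the acyl part or the aniline part gives a numerical value in this assay, and how large the step for fluoro in place of hydrogen is.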